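Phenyl to thiophene on the urea of compound 1

This account rests on a few compounds, and the source may have more. Where it says the series, first, only, none or still open, it means among the compounds named here.

Measured compounds:
compound 1 `Cc1nc(N)sc1CCCN/C(N)=N/C(=O)N[C@H](C)c1ccccc1`, 7.59 nM
compound 2 `Cc1nc(N)sc1CCCN/C(N)=N/C(=O)NC(c1ccccc1)c1ccccc1`, 39.8 nM
compound 3 `Cc1nc(N)sc1CCCN/C(N)=N/C(=S)N[C@H](C)c1ccccc1`, 89.1 nM

Three compounds share one core and differ only in the group on the urea or thiourea nitrogen. In a functional assay on Right cardiac atrium for agonist activity at histamine H2 receptor (Cavia porcellus), with a stated time of 30 min, in the presence of a further agent that is not named here (on this read-out lower numbers stand for an effect already at smaller amounts and higher numbers for an effect only at larger amounts of compound), compound 1 gives 7.59 nM, the lowest of the three numbers. Compound 2 carries a second phenyl in place of the methyl and gives 39.8 nM, a higher number that lies beyond the scatter. Compound 3 keeps the 1-phenylethyl group but has a thiocarbonyl instead of the carbonyl; in this assay compound 3 gives 89.1 nM, again well beyond the scatter from the number of compound 1. Compound 1 therefore stands clearly lowest among the measured compounds.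

Compound 4 `Cc1nc(N)sc1CCCN/C(N)=N/C(=O)NC(C)c1cccs1` has not yet been measured. It differs from compound 1 in a single place: 1-(thiophen-2-yl)ethyl in place of 1-phenylethyl on an amide-type nitrogen. Among the compounds with values here, no measured pair shows this exchange, so its effect cannot be read from the data. The carbonyl and the single aromatic ring on the ethyl linker are kept, so compound 4 is expected to behave much like compound 1, with a step of a 1.3-fold higher number from compound 1 to compound 4 (0.12 log units; within the scatter) that is expected to stay within the scatter or only slightly beyond it. Compound 4 is estimated to give 10 nM, in the range 3 nM to 32 nM.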

Compound 4, half-maximal effective concentration: 10 nM
Compound 4: the middle estimate sits on the measured number at the digits printed; measured number inside the range.
By their numbers in this assay, from the lowest: compounds 1 and 4 (each within the scatter of the next); then compound 2; then compound 3.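

In this assay, replacing 1-phenylethyl with 1-(thiophen-2-yl)ethyl on the amide-type nitrogen gives a 1.3-fold higher number from compound 1 to compound 4 (0.12 log units; within the scatter), so this place accepts a five-membered aromatic ring with one hetero atom in place of a six-membered aromatic ring of carbon only without a change beyond the scatter, even though the entering group counts one hydrogen-bond acceptor and the leaving group none. Within the data shown here, the earlier compounds showed only changes that moved the number beyond the scatter from that of compound 1, a second phenyl in compound 2 and a thiocarbonyl in compound 3, whereas compound 4 is the first to show an exchange of the aromatic ring itself, and it also carries no defined stereocentre in this group, unlike compound 1. No measured evidence explains why this exchange leaves the number within the scatter.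

The compounds shown do not separate the ring exchange from the loss of the defined stereocentre, so the contribution of each to the step remains unresolved. They also leave open how an amine or a carboxylic acid on the thiophene ring, or a propyl chain in place of the ethyl, would fare at this place.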